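Series notes: cytotoxicity, step from compound 3 to compound 4

This account rests on a few compounds, and the source may have more. Where it says the series, first, only, none or still open, it means among the compounds named here.

Measured compounds:
compound 1 `COc1cc(/C=N/NC(=O)COc2cccc3ccccc23)cc(OC)c1OC`: 13.4 ug/mL
compound 2 `O=C(COc1cccc2ccccc12)N/N=C/c1ccc([N+](=O)[O-])cc1`: 87.9 ug/mL
compound 3 `C/C(=N\NC(=O)COc1cccc2ccccc12)c1ccc(Cl)cc1`: 4.07 ug/mL

In an ADME assay on MT4 cells (Homo sapiens) for cytotoxicity, read by MTT assay, with a stated time of 4 days (on this read-out higher numbers stand for lower toxicity in this test and lower numbers for higher toxicity in this test), compound 3 stands at the lowest of the three numbers, that is, the most toxic of the set in this test. Its nearest neighbour is compound 1, which gives a higher number, a gap beyond the usual scatter; the furthest is compound 2, also higher, and well beyond the scatter. The shared core, carrying the naphthyloxy-bearing acyl hydrazone portion, is the same in all three, and only the group on the carbon with a double bond to nitrogen varies.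

Compound 4 `C/C(=N\NC(=O)COc1cccc2ccccc12)c1ccccc1Br` is not yet measured in this assay. It differs from compound 3 in one place: 2-bromophenyl in place of 4-chlorophenyl on a carbon with a double bond to nitrogen. Among the compounds with values here, no pair among the measured compounds shows this particular exchange, so nothing in the numbers so far fixes its direction.

Given that the three measured numbers spread over a wide range while compound 3 sits at the low end, and given no evidence that a halogen exchange on this aryl group matters, a small step from compound 3 to compound 4 of about a 1.4-fold higher number from compound 3 to compound 4 (0.13 log units; within the scatter) is expected, within the scatter, with low confidence. Compound 4 is therefore estimated at 5.5 ug/mL, in the range 1.6 ug/mL to 18 ug/mL.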

Compound 4, half-maximal cytotoxic concentration: 79.8 ug/mL
The estimate for compound 4 lay 15-fold (1.16 log units) below the measured number, and the stated range ends below it.
By their numbers in this assay, from the lowest: compound 3; then compound 1; then compounds 4 and 2 (each within the scatter of the next).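

In this assay, the exchange of 4-chlorophenyl for 2-bromophenyl on a carbon with a double bond to nitrogen gives a 20-fold higher number from compound 3 to compound 4 (1.29 log units; beyond the scatter), so this aryl group is not a silent part of the series: the number moves far beyond the scatter, towards lower toxicity in this test, although the heavy-atom count, the ring and the zero count of hydrogen-bond donors and acceptors all stay the same. The exchange alters the halogen and its place on the ring in a single step, and the two numbers do not divide the step between those two changes. No measurement at hand bears on what lies behind this step.

Still open, on these data alone, is where 2-chlorophenyl and 4-bromophenyl would stand at this place, since that pair would separate the identity of the halogen from its place on the ring, and where plain phenyl would stand as a reference without halogen. Also open, as far as these compounds go, is whether a ring carrying an amine or a carboxylic acid at this place would give a number near compound 3 or near compound 4.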